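The compounds below may be only part of what the source reports. "The series", "measured", "known", "first", "only" and "open" are said of these compounds alone.

Of the compounds shown here, three built on one shared core have been tested in a functional assay on MGC-803 cells (Homo sapiens) for cytotoxicity, read by MTT assay, with a stated time of 72 h; on this read-out lower numbers stand for stronger inhibition and higher numbers for weaker inhibition. Compound 1 `CCCCCCCCCCCCNc1nc(SCc2ccc(C(F)(F)F)cc2)nc2ccccc12` gives only a limit of the assay, > 50000 nM. Compound 2 `CCCCCCCCCCCCCCNc1nc(SCc2ccc(C(F)(F)F)cc2)nc2ccccc12` likewise gives only a limit, > 50000 nM. The step that the two limits leave unreadable from compound 1 to compound 2 therefore cannot be read, since the limit of > 50000 nM in this assay, at which 2 of the 3 values shown sit, is where both values sit. Among the compounds with values here, compound 3 `Cc1ccccc1Nc1nc(SCc2ccc(C(F)(F)F)cc2)nc2ccccc12` gives the one actual number in the set, 24400 nM in this assay, and so it is the sole measured point from which a step can be followed. Compound 4 `COc1ccc(Nc2nc(SCc3ccc(C(F)(F)F)cc3)nc3ccccc23)cc1` has not yet been measured. It differs from compound 3 by 4-methoxyphenyl in place of 2-methylphenyl on a nitrogen on an aromatic ring. Within the data shown here, no measured step touches the group carried on the ring nitrogen: the only step among the measured compounds concerns a saturated chain and its size is not readable. With nothing to set a direction, the step in this assay is expected to stay within the usual scatter, a 1.0-fold lower number from compound 3 to compound 4 (0.01 log units; within the scatter). Compound 4 is thus estimated at 24000 nM, with a range from 8000 nM to 50000 nM.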

Compound 4, half-maximal inhibitory concentration: 13800 nM
Beside the measured number, compound 4's estimate is 1.7-fold (0.24 log units) above it, and the stated range covers the measured number.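

In this assay, within the data shown here, replacing 2-methylphenyl with 4-methoxyphenyl on the nitrogen gives the first step that can be read at this position, a 1.8-fold lower number from compound 3 to compound 4 (0.25 log units; within the scatter). Compound 3 and compound 4 thus carry different substituted phenyl groups yet cannot be told apart within the scatter, and both give actual numbers rather than a limit of the assay. Nothing measured here speaks to the reason for this result.

From the compounds shown here alone, how a plain phenyl, a 4-chlorophenyl or a short chain such as butyl on the same nitrogen would read remains open. Going by these compounds, it is also open whether any group at this position can bring the number well below those of compound 3 and compound 4, as two phenyl groups give little sense of how far the read-out can move.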